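Swapping a bromine-bearing chain for a small oxirane ring

The compounds below may be only part of what the source reports. "The series", "measured", "known", "first", "only" and "open" are said of these compounds alone.

Of the compounds shown here, three sharing one core have been tested in a functional assay on HUVEC cells (Homo sapiens) for inhibition, read by MTT assay, with a stated time of 24 h, tested at 100 uM; on this read-out higher numbers stand for more inhibition of growth at the one concentration tested and lower numbers for less inhibition of growth. Compound 3 `COc1cc2ccc(=O)oc2cc1OCC(O)CN1CCCCC1` gives 80.7%, compound 1 `COc1cc2ccc(=O)oc2cc1OCC(=O)c1ccc(Cl)c(Cl)c1` gives 42.8%, and compound 2 `COc1cc2ccc(=O)oc2cc1OCCCCBr` gives 16.9%, the lowest of the three numbers and beyond the usual scatter below both of the others. Compound 4 `COc1cc2ccc(=O)oc2cc1OCC1CO1` has not yet been measured. It differs from compound 2 in one place: oxiran-2-yl in place of 3-bromopropyl on a saturated chain carbon bound to an oxygen on an aromatic ring. Among the compounds with values here, no two of the measured compounds differ in only a single place, so there is no measured step to lean on. The expected outcome is a modest rise in this assay at best, a step of a number 8.1 percentage points higher from compound 2 to compound 4 (within the scatter) that may not clear the scatter. For compound 4 the estimate is 25%, with a range from 10% to 50%.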

Compound 4, percent growth inhibition at one concentration: 95.5%
The estimate for compound 4 lay 70.5 percentage points below the measured number, outside the stated range (above it).
By their numbers in this assay, from the lowest: compound 2; then compound 1; then compound 3; then compound 4.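

In this assay, putting oxiran-2-yl in place of 3-bromopropyl on this saturated chain carbon brings a large rise (a number 78.6 percentage points higher from compound 2 to compound 4 (beyond the scatter)). Within the data shown here, this is the first comparison here that changes only one place, and it shows that growth inhibition responds strongly to the group carried at this position. Nothing available here explains why this change has so large an effect.

From the compounds shown here alone, whether the gain comes from gaining the oxirane ring or from losing the bromine remains open. Results for a plain butyl chain and a cyclopropyl group at this place would help separate the two.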